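Benzyl in place of propyl on the ring amine

The compounds below may be only part of what the source reports. "The series", "measured", "known", "first", "only" and "open" are said of these compounds alone.

Compound 1 `CO[C@@]12CCN(Cc3ccccc3)C[C@H]1[C@H](c1ccccc1)C(C#N)=C(N)O2`: 22600 nM
Compound 2 `CCN1CC[C@@]2(OC)OC(N)=C(C#N)[C@@H](c3ccc4ccccc4c3)[C@@H]2C1`: 28300 nM
Compound 3 `CCCN1CC[C@@]2(OC)OC(N)=C(C#N)[C@@H](c3ccc4ccccc4c3)[C@@H]2C1`: 37100 nM

In a functional assay on trachea (Cavia porcellus) (on this read-out higher numbers stand for weaker inhibition and lower numbers for stronger inhibition), compound 3 gives 37100 nM, the highest of the three numbers, though the step of a 1.3-fold higher number from compound 2 to compound 3 (0.12 log units; within the scatter) lies within the scatter, and the number of compound 1 is likewise within the scatter of that of compound 3. Compound 4 `CO[C@@]12CCN(Cc3ccccc3)C[C@H]1[C@H](c1ccc3ccccc3c1)C(C#N)=C(N)O2` is compound 3 with phenyl in place of ethyl on a saturated chain carbon bound to an amine nitrogen in a ring; cut one bond further out, the difference reads propyl to benzyl. Among the measured compounds shown here, the only step that bears on this change is the chain lengthening a 1.3-fold higher number from compound 2 to compound 3 (0.12 log units; within the scatter), which was within the scatter. Compound 1, which also carries a benzyl on the ring amine but a phenyl rather than a naphthyl group on the core, gives 22600 nM, again within the scatter of compounds 2 and 3. Nothing here points to a shift beyond the scatter, so compound 4 is expected to show a 1.3-fold lower number from compound 3 to compound 4 (0.12 log units; within the scatter) in this assay. Compound 4 is therefore estimated at 28000 nM, between 12000 nM and 65000 nM.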

Compound 4, half-maximal inhibitory concentration: 23400 nM
Compound 4: the middle estimate sits 1.2-fold (0.08 log units) above what was measured, and the stated range covers the measured number.
By their numbers in this assay, from the lowest: compounds 1, 4, 2 and 3 (each within the scatter of the next).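

Phenyl in place of ethyl on a saturated chain carbon bound to an amine nitrogen in a ring, which reads as propyl to benzyl, gives a 1.6-fold lower number from compound 3 to compound 4 (0.20 log units; within the scatter) in this assay, and phenyl in place of methyl on that carbon gives a 1.2-fold lower number from compound 2 to compound 4 (0.08 log units; within the scatter). A six-membered aromatic ring at this position thus leaves the number within the scatter, as the chain lengthening did. With benzyl kept, naphthalen-2-yl in place of phenyl on a saturated ring carbon gives a 1.0-fold higher number from compound 1 to compound 4 (0.02 log units; within the scatter), and no evidence is at hand to account for how close these numbers lie.

The compounds shown leave open whether a longer chain at this position, or a carboxylic acid or an amine on the phenyl of the benzyl, would move the number beyond the scatter. They also leave open whether any group on the shared core would do so.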